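The compounds below may be only part of what the source reports. "The series", "measured", "known", "first", "only" and "open" are said of these compounds alone.

Measured so far:
compound 1 `Cc1cc(NC(=O)Cn2nnc(-c3ccccc3)n2)n(C(C)C)n1` — 107%
compound 2 `Cc1cc(NC(=O)Cn2nnc(-c3ccccc3)n2)n(Cc2ccccc2)n1` — 74%
compound 3 `Cc1cc(NC(=O)Cn2nnc(-c3ccc(F)cc3)n2)n(C2CCCCC2)n1` — 92%

These three compounds share one core and were read in an assay on HEK293 cells for activation of Kir3.1/Kir3.2 (Homo sapiens), read by thallium flux; a lower number here means a smaller maximal response, a higher number a larger maximal response. Within the data shown here, compound 1 gives 107% and compound 2 gives 74%; the only single-point step among them, a number 33 percentage points lower from compound 1 to compound 2 (beyond the scatter), is the one measured step in this set. Compound 3 gives 92% and sits between the other two: its number lies below that of compound 1 and above that of compound 2, both gaps beyond the scatter.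

Compound 4 `COc1cccc(-c2nnn(CC(=O)Nc3cc(C)nn3C3CCCCC3)n2)c1` has not yet been measured. Relative to compound 3 the change is 3-methoxyphenyl in place of 4-fluorophenyl on an aromatic carbon. Among the measured compounds shown here, no measured step touches this part of the molecule: the step from compound 1 to compound 2 concerns the group on the aromatic nitrogen, not the aryl group on the aromatic carbon, so it says nothing direct about compound 4. Compound 1 and compound 3 differ in more than one place, so their gap cannot be assigned to the aryl group alone.

For the measured compounds named here, with no step bearing on the change, the expectation for compound 4 is a step of no change at the digits printed from compound 3 to compound 4 (within the scatter), within the scatter. Compound 4 is therefore estimated at 92%, in a range from 65% to 115%.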

Compound 4, largest response reached (Emax), in percent of the reference or control that the assay uses: 76%
The estimate for compound 4 lay 16 percentage points above the measured number; the range from low to high includes it.
By their numbers in this assay, from the lowest: compounds 2 and 4 (each within the scatter of the next); then compound 3; then compound 1.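

Among these compounds, the swap at the aromatic carbon of the five-membered ring with 4 nitrogen gives the first measured step for the aryl group: in this assay there is a number 16 percentage points lower from compound 3 to compound 4 (beyond the scatter), so with the rest of the molecule unchanged, this part of the structure does affect the maximal response. Among the compounds shown here, the single step changes two things at once, since 3-methoxyphenyl differs from 4-fluorophenyl both in its substituent and in where that substituent sits on the phenyl ring, and it adds one heavy atom and one hydrogen-bond acceptor, so the size of the drop cannot be assigned to any one of these. Nothing available here gives a reason for the lower response.

The compounds shown leave open whether the drop follows the methoxy group or its place on the ring, a question that 4-methoxyphenyl or 3-fluorophenyl at the same carbon would address. Going by these compounds, it also remains open how an amine or a carboxylic acid on the phenyl ring would read here, and whether the aryl change has the same effect with isopropyl or benzyl on the aromatic nitrogen.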